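Same Atoms, Different Ring: A Microsomal Stability Step

A few compounds are considered here, and "the series" means these few. Any claim that something is new, unique, unknown or untested is made for them only; others in the source may bear on it.

Among the compounds with values here, compound 1 `O=C(O)c1cnnc(C2=C(c3cc(Cl)ccc3OCc3ccc(F)cc3F)CCC2)c1` is the only member of this set with a number in an in vitro ADME assay on microsomes from liver (Rattus norvegicus) for metabolic stability; a higher number here means faster removal of the compound, a lower number slower removal: compound 1 gives 14 mL/min/kg. Compound 2 `O=C(O)c1cc(C2=C(c3cc(Cl)ccc3OCc3ccccc3)CCC2)cnn1` belongs to the same series, but in this assay compound 2 gives "not determined" (no result reported). Compound 3 `O=C(O)c1cc(C2=C(c3cc(C(F)(F)F)ccc3OCc3ccccc3)CCC2)ccn1` belongs to the same series too, and in this assay compound 3 gives "not determined" (no result reported). The untested compound 4 `O=C(O)c1cncc(C2=C(c3cc(Cl)ccc3OCc3ccc(F)cc3F)CCC2)n1` differs from compound 1 in a single place, (6-carboxypyrazin-2-yl in place of 5-carboxypyridazin-3-yl on a double-bonded ring carbon), so the two share every atom and differ only in how those atoms are joined. Within the data shown here, no step between two measured compounds is available, so the expectation rests on compound 1 alone: a move in this assay no larger than the usual scatter, in either direction, is expected. Compound 4 is estimated at 16 mL/min/kg, with a range from 7 mL/min/kg to 35 mL/min/kg. This corresponds to an expected step of a 1.1-fold higher number from compound 1 to compound 4 (0.06 log units; within the scatter).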

Compound 4, clearance in the Rattus norvegicus assay: 2.6 mL/min/kg
Compound 4: the middle estimate sits 6.2-fold (0.79 log units) above what was measured; measured number below the stated range.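

The position on the double-bonded ring carbon proved sensitive to ring arrangement alone: with the same atoms joined differently, 6-carboxypyrazin-2-yl in place of 5-carboxypyridazin-3-yl gave in the Rattus norvegicus assay a 5.4-fold lower number from compound 1 to compound 4 (0.73 log units; beyond the scatter). The same change also moved lipophilicity, since in a physicochemical assay for lipophilicity (on this read-out higher numbers stand for higher lipophilicity and lower numbers for lower lipophilicity), compound 1 gives 1.2 and compound 4 gives 1.6, a difference beyond the scatter. The compounds shown leave open whether the slower removal is tied to that higher lipophilicity. They also leave open whether it would persist with a tetrazole or a primary amide in place of the carboxylic acid.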